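The source may hold more compounds than are shown below. What is called first, only, known or untested is meant among the compounds shown, and "the series" means these compounds.

Series notes. Going by the values given here, compound 2 `COC(=O)c1c(N)sc(-c2ccc(Cl)cc2)c1-c1ccc(Cl)cc1` gives the lowest number so far in a functional assay on PC-3 cells (Homo sapiens) for cytotoxicity, read by sulforhodamine B assay, with a stated time of 72 h (a lower number here means a stronger inhibitor, a higher number a weaker inhibitor), at 2780 nM. In this assay, among the compounds with values here, compound 1 `Nc1sc(-c2ccccc2)c(-c2ccc(Cl)cc2)c1C(=O)NC1CC1` gives 17100 nM; it differs from compound 2 in more than one place, so no single step connects the two, and the gap between their numbers lies beyond the scatter. Compound 3 `Nc1sc(-c2ccc(Cl)cc2)c(-c2ccc(Cl)cc2)c1C(=O)N1CCCC1` has not yet been measured. It differs from compound 2 in one place: pyrrolidin-1-yl in place of methoxy on a carbonyl carbon. Within the data shown here, no measured pair isolates this change, so its direction cannot be read from a direct precedent. Compound 1, which likewise carries no methoxycarbonyl group, stands at the higher of the two numbers, and this carries some weight, although its further difference from compound 2 prevents a clean reading. The step is therefore expected to be a modest rise in the number, a 1.8-fold higher number from compound 2 to compound 3 (0.25 log units; within the scatter), which may or may not exceed the scatter. Compound 3 is estimated at 5000 nM in this assay, with a range from 1500 nM to 20000 nM, the width reflecting the absence of any matched precedent.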

Compound 3, half-maximal inhibitory concentration: 6220 nM
The estimate for compound 3 lay 1.2-fold (0.09 log units) below the measured number; the measured number falls inside the stated range.
By their numbers in this assay, from the lowest: compound 2; then compound 3; then compound 1.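

In this assay the carbonyl carbon whose other neighbour is an aromatic carbon responds to the group it carries: a 2.2-fold higher number from compound 2 to compound 3 (0.35 log units; beyond the scatter), which gives the series its first change in a single place, with pyrrolidin-1-yl replacing methoxy. The step is modest, so the methoxycarbonyl group is not essential for a measurable number in this assay, and an amide on this carbon remains workable on the core shared by compound 2 and compound 3. Going by these compounds alone, with only this one pair, the result describes this single exchange and sets no trend for the position, and no measurement in hand bears on why the number rises with this change.

As far as these compounds go, it remains open whether the rise follows from the pyrrolidine ring itself or from the change of ester to amide; a dimethylamino group or a piperidin-1-yl ring on the same carbonyl carbon would help separate the two. From the compounds shown here alone, the response of this carbon to a free carboxylic acid or to a longer ester such as ethoxycarbonyl also remains unknown.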